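The compounds below may be only part of what the source reports. "The series", "measured", "known", "first", "only" and "open" are said of these compounds alone.

The two measured compounds share one core and differ only in the aryl group attached to it. Compound 1 `COc1ccc(-c2nc3c(NC4CCCC4)cccn3c2-c2ccnc(NC3CCCC3)n2)cc1` carries a 4-methoxyphenyl group, while compound 2 `COc1cccc(-c2nc3c(NC4CCCC4)cccn3c2-c2ccnc(NC3CCCC3)n2)c1` carries a 3-methoxyphenyl group. In an ADME assay on Vero cells (Chlorocebus sabaeus) for cytotoxicity (on this read-out lower numbers stand for higher toxicity in this test and higher numbers for lower toxicity in this test), compound 1 gives > 10000 nM, which is a limit of the assay rather than a number. In this assay compound 2 gives > 40000 nM, again a limit and not a number. The step that the two limits leave unreadable from compound 1 to compound 2 therefore has no readable size. Compound 2 stands at the limit of > 40000 nM in this assay, at which 1 of the 2 values shown sits. Compound 1 stands at the limit of > 10000 nM in this assay, at which 1 of the 2 values shown sits. Compound 3 `Cc1ccc(-c2nc3c(NC4CCCC4)cccn3c2-c2ccnc(NC3CCCC3)n2)cc1` brings the next change: 4-methylphenyl in place of 3-methoxyphenyl on an aromatic carbon. Among the compounds with values here, no measured step bears on this change with a readable size; the only guidance is that both measured compounds sit at limits, showing little toxicity. The step of a number no higher from compound 2 to compound 3 (the limit leaves the size open) is the expected outcome, that is, no change beyond the scatter. Compound 3 is estimated at 40000 nM, expected between 10000 nM and 100000 nM, most likely reported as a limit again.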

Compound 3, half-maximal cytotoxic concentration: > 40000 nM
Compound 3: no number, only a limit; the forecaster's own chance of this, stated with the estimate: 80%; the middle value lies on the limit itself.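

Within the data shown here, compound 1, compound 2 and compound 3 all give limits rather than numbers, and no step between them can be read. On these data alone, what stays open in this assay is the concentration at which any of the three turns toxic, and whether changing the aryl group shifts it.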